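Moving One Amino Group: From 4-Aminophenyl to 3-Aminophenyl

This account rests on a few compounds, and the source may have more. Where it says the series, first, only, none or still open, it means among the compounds named here.

In a functional assay on HuT78 cells (Homo sapiens) for cytotoxicity, with a stated time of 48 h (on this read-out lower numbers stand for stronger inhibition and higher numbers for weaker inhibition), compound 1 (`COc1ccc(/C=C\c2ccc3c(c2)C(C)(C)CCC3(C)C)cc1N`) gives 22000 nM and compound 2 (`CC1(C)CCC(C)(C)c2cc(/C=C\c3ccc(N)cc3)ccc21`) gives 43000 nM as its reading. Going by the values given here, these two values lie within the scatter of each other, so compound 2 stands level with compound 1 on the numbers so far. Among the compounds with values here, compound 3 (`CC1(C)CCC(C)(C)c2cc(/C=C\c3cccc(N)c3)ccc21`) has the same atoms as compound 2, joined differently: 3-aminophenyl in place of 4-aminophenyl on a double-bonded chain carbon bound to a double-bonded chain carbon is the only change. Within the data shown here, no measured pair shows what this swap does. The estimated step of a 1.2-fold lower number from compound 2 to compound 3 (0.09 log units; within the scatter) stays within the scatter, so no real change in either direction is expected. Compound 3 is expected to give 35000 nM (estimated range 12000 nM to 90000 nM).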

Compound 3, half-maximal inhibitory concentration: 5000 nM
For compound 3 the middle estimate is 7.0-fold (0.85 log units) above the measured one; measured number below the stated range.
By their numbers in this assay, from the lowest: compound 3; then compounds 1 and 2 (each within the scatter of the next).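

In this assay, the place of the amino group matters: 3-aminophenyl in place of 4-aminophenyl, with the same atoms, gives an 8.6-fold lower number from compound 2 to compound 3 (0.93 log units; beyond the scatter). Hydrogen in place of methoxy on an aromatic carbon gives a 4.4-fold lower number from compound 1 to compound 3 (0.64 log units; beyond the scatter), so the 3-aminophenyl compound without methoxy has the lowest number of the three. Nothing available here explains either step. The compounds shown leave open whether a hydroxyl group or a carboxylic acid in place of the amino group of 3-aminophenyl would keep this lower number.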